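Small Steps in Liver Cell Cytotoxicity Among Aryl Variants

The source may hold more compounds than are shown below. What is called first, only, known or untested is meant among the compounds shown, and "the series" means these compounds.

In an ADME assay on L02 cells (Homo sapiens) for cytotoxicity, read by MTT assay, with a stated time of 24 h (on this read-out higher numbers stand for weaker inhibition and lower numbers for stronger inhibition), compound 1 `COc1cc(/C=C2\CN(C)C/C(=C\c3ccc(F)cc3)C2=O)cc(OC)c1` gives 21900 nM, compound 2 `COc1cc(/C=C2\CN(C)C/C(=C\c3ccc(Br)cc3)C2=O)cc(OC)c1` gives 21300 nM and compound 3 `COc1cc(/C=C2\CN(C)C/C(=C\c3ccc(Cl)c(Cl)c3)C2=O)cc(OC)c1` gives 10600 nM. Compound 3 holds the lowest of these three numbers, and the two steps reaching it are a 2.1-fold lower number from compound 1 to compound 3 (0.32 log units; beyond the scatter) and a 2.0-fold lower number from compound 2 to compound 3 (0.30 log units; within the scatter). Exchanging fluoro for bromo gives a 1.0-fold lower number from compound 1 to compound 2 (0.01 log units; within the scatter).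

Compound 4 `COc1cc(/C=C2\CN(C)C/C(=C\c3cccc([N+](=O)[O-])c3)C2=O)cc(OC)c1` carries 3-nitrophenyl in place of 3,4-dichlorophenyl on a double-bonded chain carbon bound to a double-bonded ring carbon. Within the data shown here, no measured compound carries this group, so the earlier steps can only suggest a size. The largest of them, a 2.1-fold lower number from compound 1 to compound 3 (0.32 log units; beyond the scatter), is modest, and it came with the arrival of the group that compound 4 gives up. A small move toward a higher number in this assay is therefore expected, with the estimated change being a 1.5-fold higher number from compound 3 to compound 4 (0.18 log units; within the scatter), not clearly beyond the scatter. For compound 4 the expected value is 16000 nM, within an estimated range of 7500 nM to 34000 nM.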

Compound 4, half-maximal inhibitory concentration: 10800 nM
The estimate for compound 4 lay 1.5-fold (0.17 log units) above the measured number; the measured number falls inside the stated range.
By their numbers in this assay, from the lowest: compounds 3, 4, 2 and 1 (each within the scatter of the next, the first and the last beyond it).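

In this assay, 3-nitrophenyl and 3,4-dichlorophenyl, groups that share only the aromatic ring, cannot be told apart at this place on a double-bonded chain carbon bound to a double-bonded ring carbon (a 1.0-fold higher number from compound 3 to compound 4 (0.01 log units; within the scatter)). Compound 4 also stands where compound 3 stood relative to the other two, within the scatter of the bromo compound (a 2.0-fold lower number from compound 2 to compound 4 (0.29 log units; within the scatter)) and just beyond it for the fluoro compound (a 2.0-fold lower number from compound 1 to compound 4 (0.31 log units; beyond the scatter)), so the low end of this small set no longer rests on a chlorine-bearing group alone. No supporting measurement bears on this result, and the data give no cause for it.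

From the compounds shown here alone, only substituted phenyl groups appear at this place, so it stays open whether an amine, a carboxylic acid or a longer chain would read in the same range. Going by these compounds, how an unsubstituted phenyl would read beside these groups also stays open.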